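The source may report more compounds than this note shows. Statements on the series, on what has been measured and on what is new or still open speak of the compounds shown alone.

Working notes on the series in a functional assay on cells (Cancer cell lines, Homo sapiens) for cytotoxicity, read by sulforhodamine B assay, with a stated time of 48 h; a lower number here means a stronger inhibitor of growth, a higher number a weaker inhibitor of growth.

Three compounds carry a shared core with a 2,5-dimethoxyphenyl group. Compound 1 `COc1ccc(OC)c(-c2cc(-c3ccccc3)nn2-c2ccc(S(N)(=O)=O)cc2)c1` gives 29800 nM. Compound 2 `COc1ccc(OC)c(-c2cc(-c3ccccc3)nn2-c2ccc(S(=O)(=O)NC(C)=O)cc2)c1` gives 37700 nM. Compound 3 `COc1ccc(OC)c(-c2cc(-c3ccc(Cl)cc3)nn2-c2ccc(S(=O)(=O)NC(C)=O)cc2)c1` gives 53200 nM. On these three numbers compound 2 holds the second highest value; its nearest neighbour is compound 1 and its furthest is compound 3, and both of those gaps are within the scatter, so the three are not separable on this assay.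

The two measured steps are small: a 1.3-fold higher number from compound 1 to compound 2 (0.10 log units; within the scatter) and a 1.4-fold higher number from compound 2 to compound 3 (0.15 log units; within the scatter). Each touches a different part of the molecule, the sulfonamide nitrogen and the phenyl ring, and neither moves the number beyond the scatter.

Compound 4 `CC(=O)NS(=O)(=O)c1ccc(-n2nc(-c3ccccc3)cc2-c2cc(O)ccc2O)cc1` differs from compound 2 by 2,5-dihydroxyphenyl in place of 2,5-dimethoxyphenyl on an aromatic carbon. Within the data shown here, no measured step touches this group, so nothing here speaks directly to the change; the only guidance is that the two changes tried so far left this assay essentially flat. From the compounds shown here alone, the expected step is therefore a 1.1-fold lower number from compound 2 to compound 4 (0.03 log units; within the scatter), that is, no change beyond the scatter, with a wide range because the change is untested. For compound 4 the estimated value in this assay is 35000 nM, expected between 12000 nM and 90000 nM.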

Compound 4, concentration for total growth inhibition: 100000 nM
Estimate against measurement, compound 4: 2.9-fold (0.46 log units) below, and the stated range ends below it.
By their numbers in this assay, from the lowest: compounds 1, 2, 3 and 4 (each within the scatter of the next, the first and the last beyond it).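

In this assay, among these compounds, 2,5-dihydroxyphenyl in place of 2,5-dimethoxyphenyl gives a 2.7-fold higher number from compound 2 to compound 4 (0.42 log units; beyond the scatter), the only step so far that lies beyond the scatter, and it runs toward weaker growth inhibition. Among the compounds shown here, this position, on an aromatic carbon of a five-membered aromatic ring with 2 nitrogen, next to the ring nitrogen, is therefore not flat in the way the earlier steps at the sulfonamide nitrogen and on the phenyl ring were, and a change here can register in this read-out even though the step is modest. No measurement at hand accounts for the step, so it cannot be assigned to the hydrogen-bond donors that enter or to the methyl groups that leave.

Open, from the compounds shown here alone, is how a phenyl group carrying one methoxy and one hydroxyl, a 2,5-diethoxyphenyl group or an unsubstituted phenyl would read at this place, which would show whether both oxygen substituents matter and in which form. Also open, going by these compounds, is whether the same step holds alongside the free sulfonamide of compound 1 or the chloro group of compound 3.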